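Methoxy for methyl on the shared core: what follows

This account rests on a few compounds, and the source may have more. Where it says the series, first, only, none or still open, it means among the compounds named here.

In an ADME assay on the whole organism with Oryza sativa as the target, tested at 1 uM (a higher number here means a weaker effect of the compound at the concentration tested, a lower number a stronger effect), compound 1 `Cc1ccccc1NC(=O)N[C@H](C)c1ccccc1` gives 100%, compound 2 `Cc1ccccc1NC(=O)N[C@@H](C)c1ccccc1` gives 99% and compound 3 `C[C@H](NC(=O)Nc1cccc(C(F)(F)F)c1)c1ccccc1` gives 93%; all three numbers sit within the usual scatter of one another. Going by the values given here, the only step between neighbours, a number 1 percentage points lower from compound 1 to compound 2 (within the scatter), rests on the fact that compounds 1 and 2 differ only in the configuration as drawn and leaves the number unchanged. Compound 4 `COc1ccccc1NC(=O)N[C@H](C)c1ccccc1` differs from compound 1 by methoxy in place of methyl on an aromatic carbon. Among the compounds with values here, no measured step alters a group on that ring, so the change cannot be weighed against any precedent of its kind; the one step available was flat. He therefore expects in this assay no shift beyond the scatter, a number 3 percentage points lower from compound 1 to compound 4 (within the scatter), and estimates for compound 4 a value of 97%, most likely between 87% and 100%.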

Compound 4, a percentage reported as activity, at one concentration (the size of the read-out at that concentration, not a potency): 105%
The estimate for compound 4 lay 8 percentage points below the measured number, outside the stated range (above it).
By their numbers in this assay, from the lowest: compounds 3, 2, 1 and 4 (each within the scatter of the next, the first and the last beyond it).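

In this assay the step of a number 5 percentage points higher from compound 1 to compound 4 (within the scatter) is the only one shown that alters a group on this ring. At this place, on an aromatic carbon ortho to a large group, exchanging methyl for methoxy adds one oxygen and one hydrogen-bond acceptor, yet the change stays within the scatter. Nothing available bears on why this step behaves as it does. The compounds shown leave open whether an amine, a carboxylic acid or a longer chain such as ethoxy at this place would move the number beyond the scatter. They also leave open whether methoxy behaves alike on compound 2.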